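Swapping a Bromophenyl for a Dichlorophenyl at Adenosine A2b

The compounds below may be only part of what the source reports. "The series", "measured", "known", "first", "only" and "open" are said of these compounds alone.

Compound 1 `O=C(CCc1ccccc1)Nc1nc2ccccc2c(=O)s1` gives 365 nM in an assay on CHO cells for displacement of a labelled ligand from adenosine receptor A2b (Homo sapiens), read by scintillation counting, with a stated time of 75 min; on this read-out lower numbers stand for stronger inhibition and higher numbers for weaker inhibition. Compound 2 `O=C(CCc1ccccc1Br)Nc1nc2ccccc2c(=O)s1` sits at the limit of > 1000 nM in this assay, at which 1 of the 2 values shown sits; in this assay compound 2 gives > 1000 nM, which is a limit of the measurement rather than a number. Going by the values given here, the one measured step, an at least 2.7-fold higher number from compound 1 to compound 2 (0.43 log units; beyond the scatter), weakened binding. Compound 3 `O=C(CCc1ccc(Cl)c(Cl)c1)Nc1nc2ccccc2c(=O)s1` differs from compound 2 by 3,4-dichlorophenyl in place of 2-bromophenyl on a saturated chain carbon, two bonds along the chain from a carbonyl carbon. Among the compounds with values here, because the only related change weakened binding in an at least 2.7-fold higher number from compound 1 to compound 2 (0.43 log units; beyond the scatter), compound 3 is expected to remain weak, with an estimated step that the limit leaves unreadable from compound 2 to compound 3. Compound 3 is therefore estimated at 1300 nM, most likely between 400 nM and 4000 nM.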

Compound 3, inhibition constant: > 1000 nM
Compound 3 was reported as a limit; the forecaster's own chance of this, stated with the estimate: 55%; the middle value lies beyond the limit too.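

In this assay, 3,4-dichlorophenyl in place of phenyl gives an at least 2.7-fold higher number from compound 1 to compound 3 (0.43 log units; beyond the scatter), so a phenyl ring carrying two chlorines goes the same way as the 2-bromophenyl ring. The step from compound 2 to compound 3 cannot be read because both compounds sit at the same limit of the assay: the limit of > 1000 nM in this assay, at which 2 of the 3 values shown sit.

Which of these two compounds binds less well stays open, as does whether any group on this phenyl ring can improve on compound 1. Also open, as far as these compounds go, is how an amine on the ring, or a longer chain, would fare in this assay.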